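The compounds below may be only part of what the source reports. "The series", "measured", "known", "first", "only" and "open" are said of these compounds alone.

Measured compounds in a functional assay on MCF7 cells (Homo sapiens) for inhibition, read by sulforhodamine B assay; on this read-out higher numbers stand for weaker inhibition of growth and lower numbers for stronger inhibition of growth:
- compound 1 `FC(F)(F)c1ccc(-c2ccc(-c3ccc(-c4nc5ccccc5[nH]4)cc3)cc2)cc1`: 41400 nM
- compound 2 `Cc1ccc2[nH]c(-c3ccc(-c4ccc(-c5ccccc5)cc4)cc3)nc2c1`: 31600 nM

Only these two compounds have been measured so far. In this assay, compound 2 gives 31600 nM and stands level with compound 1 at 41400 nM, since the two values lie within the usual scatter of each other. Among the compounds with values here, the two do not differ in a single place, so no measured step is available as a guide.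

The next compound to be tested is compound 3 `Cc1ccc2[nH]c(-c3ccc(-c4ccc(-c5ccc(C(F)(F)F)cc5)cc4)cc3)nc2c1`. It is compound 2 with trifluoromethyl in place of hydrogen on an aromatic carbon, on a six-membered aromatic ring of carbon only, para to a large group: trifluoromethyl in place of hydrogen on an aromatic carbon.

Compound 1 also carries a 4-(trifluoromethyl)phenyl end and gives 41400 nM, which offers no sign that this group moves the number away from that of compound 2 at 31600 nM. No step beyond the scatter is therefore expected, and the estimated change is a 1.1-fold higher number from compound 2 to compound 3 (0.04 log units; within the scatter). For compound 3 the estimated value is 35000 nM, with an expected range of 15000 nM to 80000 nM.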

Compound 3, concentration for 50% growth inhibition: 31000 nM
For compound 3 the middle estimate is 1.1-fold (0.05 log units) above the measured one, and the stated range covers the measured number.
By their numbers in this assay, from the lowest: compounds 3, 2 and 1 (each within the scatter of the next).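

In this assay, within the data shown here, compound 2 and compound 3 form the first pair that differs in one place, and phenyl to 4-(trifluoromethyl)phenyl gives a 1.0-fold lower number from compound 2 to compound 3 (0.01 log units; within the scatter). Among these compounds, with methyl on the core, trifluoromethyl in place of hydrogen on this aromatic carbon therefore leaves the read-out level, which the earlier compounds could only suggest across two differences. The second single change, methyl in place of hydrogen on an aromatic carbon with the 4-(trifluoromethyl)phenyl end held fixed, gives a 1.3-fold lower number from compound 1 to compound 3 (0.13 log units; within the scatter), so this change also stays level and neither step separates the compounds; no evidence is available that bears on these results.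

The compounds shown leave open whether any other group at this place, such as an amine, a carboxylic acid or a longer chain, would give a step beyond the scatter. They also leave open whether a group other than methyl on the core, such as a methoxy group or chlorine, would do so, and whether such a change would behave alike with and without the trifluoromethyl end.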